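This account rests on a few compounds, and the source may have more. Where it says the series, first, only, none or still open, it means among the compounds named here.

Of the compounds shown here, three built on one shared core have been tested in a functional assay, with a stated time of 150 min, tested at 35 ug/mL; a higher number here means a stronger effect of the compound at the concentration tested, a lower number a weaker effect. Compound 1 `COC(=O)c1c(Nc2ccc(Cl)cc2)sc(C(=O)c2ccc(OC)cc2)c1C` was reported in this assay as "not active" (no number reported). Compound 2 `COC(=O)c1c(Nc2ccccc2)sc(C(=O)c2ccc(C)cc2)c1C` gives 10.3% in this assay. Compound 3 `COC(=O)c1c(Nc2ccc(F)cc2)sc(C(=O)c2ccc(C)cc2)c1C` was reported in this assay as "not active" (no number reported), so no number stands for it; compound 1 is the one further entry that likewise carries no number. Compound 4 `COC(=O)c1c(Nc2ccc(Cl)cc2)sc(C(=O)c2ccc(C)cc2)c1C` has not yet been measured. It differs from compound 3 in one place: chloro in place of fluoro on an aromatic carbon. For the measured compounds named here, no measured pair shows this change directly. Since compound 1 was reported as "not active" (no number reported) and compound 2 gives only 10.3%, a small effect, if any beyond the scatter, is expected for compound 4. Compound 4 is expected to give about 5% in this assay, within 0% to 15%.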

Compound 4, a percentage reported as activity, at one concentration (the size of the read-out at that concentration, not a potency): "not active" (no number reported)
For compound 4 the study gives words and no number, and the estimate cannot be compared.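

Compound 3 and compound 4 are both reported in this assay in words without a number, so no step can be read between them. The compounds shown leave open whether swapping fluoro for chloro changes the effect at all. No measurement shown here offers an explanation for this result.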